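The source may hold more compounds than are shown below. What is called first, only, known or untested is meant among the compounds shown, and "the series" means these compounds.

Measured so far in a physicochemical assay for lipophilicity, at pH 7.4; on this read-out higher numbers stand for higher lipophilicity and lower numbers for lower lipophilicity:
- Compound 1 `Cc1cc(/C=C/C#N)cc(C)c1Oc1cc(Nc2ccc(C#N)cc2)c(N)cc1C(N)=O`: 3.53
- Compound 2 `CC(=O)CCc1cc(C)c(Oc2cc(Nc3ccc(C#N)cc3)c(N)cc2C(F)(F)F)c(C)c1`: > 5, a limit of the assay
- Compound 3 `CNC(=O)c1cc(N)c(Nc2ccc(C#N)cc2)cc1Oc1c(C)cc(CCC#N)cc1C`: 2.65

Among the compounds with values here, only two of these readings are actual numbers. Compound 2 gives only a limit, > 5. Of the two numbers, compound 3 holds the lower, 2.65. Its nearest neighbour is compound 1 at 3.53, a gap beyond the usual scatter of repeated measurements.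

Compound 4 `Cc1cc(CCC#N)cc(C)c1Oc1cc(Nc2ccc(C#N)cc2)c(N)cc1CO` has no value yet. It differs from compound 3 in one place: hydroxymethyl in place of methylcarbamoyl on an aromatic carbon, meta to an amino group and para to a (4-cyanophenyl)amino group (hydroxymethyl in place of methylcarbamoyl on an aromatic carbon). Within the data shown here, no two measured compounds differ in only one place, and none shows this exchange directly, which makes any expectation a rough one.

The estimate starts from compound 3 at 2.65, with compound 1 at 3.53 showing that higher numbers occur among these compounds. A moderate rise beyond the scatter is expected, a number 0.55 log units higher from compound 3 to compound 4 (beyond the scatter). In this assay the estimate for compound 4 is 3.2, with an expected range of 2.7 to 3.9.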

Compound 4, partition coefficient: 3.68
Compound 4: the middle estimate sits 0.48 log units below what was measured, and the stated range covers the measured number.
By their numbers in this assay, from the lowest: compound 3; then compounds 1 and 4 (each within the scatter of the next). At a limit, above all of these: compound 2.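

In this assay, within the data shown here, this is the first exchange seen at a single place on the shared core: a number 1.03 log units higher from compound 3 to compound 4 (beyond the scatter), a large step, with hydroxymethyl in place of methylcarbamoyl on the aromatic carbon para to a (4-cyanophenyl)amino group. The group at this position therefore matters on this read-out, and the exchange goes from 4 heavy atoms to 2 and loses the double bond outside aromatic rings, while each group counts 1 hydrogen-bond donor and 1 hydrogen-bond acceptor, so those two counts stay the same. Nothing measured here accounts for the size of the step.

A single step cannot show whether the rise follows from the smaller group, from the loss of the carbonyl, or from something else in the exchange, nor whether it would hold with other parts of the molecule changed. Going by these compounds, how a carboxylic acid, an aminomethyl group or a longer hydroxyalkyl chain would read at this position remains open, and such groups would show whether the numbers here follow any trend.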